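Removing the piperidin-1-yl group from compound 2

The source may report more compounds than this note shows. Statements on the series, on what has been measured and on what is new or still open speak of the compounds shown alone.

Compound 1 `CC(C)(C)c1ccc2c(c1)OCCC2NC(=O)Nc1cccc2[nH]ncc12`: 43 nM
Compound 2 `O=C(Nc1cccc2[nH]ncc12)NC1CCOc2c1cccc2N1CCCCC1`: 16 nM

In a functional assay for antagonist activity at transient receptor potential cation channel subfamily V member 1 (Homo sapiens), read by calcium flux (on this read-out higher numbers stand for weaker inhibition and lower numbers for stronger inhibition), compound 2 gives the lowest number of the two, and compound 1 sits beyond the scatter with its higher value. Compound 3 `O=C(Nc1cccc2[nH]ncc12)NC1CCOc2ccccc21` differs from compound 2 in one place: hydrogen in place of piperidin-1-yl on an aromatic carbon. Among the measured compounds shown here, no measured pair shows this change, so its size is unknown. Because compound 2 gives 16 nM while carrying the group that compound 3 lacks, compound 3 is expected to return a weaker result, with a step of a 9.4-fold higher number from compound 2 to compound 3 (0.97 log units; beyond the scatter) estimated beyond the scatter. Compound 3 is expected near 150 nM, within 50 nM to 500 nM.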

Compound 3, half-maximal inhibitory concentration: 234 nM
Estimate against measurement, compound 3: 1.6-fold (0.19 log units) below; measured number inside the range.
By their numbers in this assay, from the lowest: compound 2; then compound 1; then compound 3.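

In this assay the aromatic carbon proves far from indifferent: hydrogen in place of piperidin-1-yl gives a 15-fold higher number from compound 2 to compound 3 (1.17 log units; beyond the scatter) and counts as a large step. Hydrogen in place of tert-butyl gives a 5.4-fold higher number from compound 1 to compound 3 (0.74 log units; beyond the scatter) and counts as a modest one, so among these three compounds the unsubstituted one has the highest number, and either group lowers it. On these data alone, whether a smaller amine such as dimethylamino, or a morpholine ring, would hold the lower number on this carbon remains open. Nothing given here explains either step.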